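A few compounds are considered here, and "the series" means these few. Any claim that something is new, unique, unknown or untested is made for them only; others in the source may bear on it.

Measured so far:
compound 1 `CC(C)NC(=O)N1CCN(C(=S)SCc2cn(Cc3ccccc3F)nn2)CC1` — in a functional assay on MCF7 cells (Homo sapiens) for cytotoxicity, read by MTT assay, with a stated time of 72 h (a lower number here means a stronger inhibitor, a higher number a weaker inhibitor), compound 1 gives 1860 nM
compound 2 `CCNC(=O)N1CCN(C(=S)SCc2cn(Cc3ccc(C)cc3)nn2)CC1` — compound 2 gives only a limit, > 128000 nM

Compound 2 stands at a limit of this assay and not at a number; of the two values shown, it is the one sitting at the limit of > 128000 nM in this assay, at which 1 of the 2 values shown sits. Compound 3 `Cc1ccc(Cn2cc(CSC(=S)N3CCN(C(=O)NC(C)C)CC3)nn2)cc1` differs from compound 2 by methyl in place of hydrogen on a saturated chain carbon bound to an amide-type nitrogen and a saturated chain carbon. For the measured compounds named here, no step between measured compounds is known, and compound 1 shares the isopropylcarbamoyl group but differs elsewhere as well, so its value only marks a possibility. The step from compound 2 to compound 3 is expected to run toward stronger inhibition, of uncertain size, an at least 6.4-fold lower number from compound 2 to compound 3 (0.80 log units; beyond the scatter). Compound 3 is estimated at 20000 nM, within 2000 nM to 200000 nM.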

Compound 3, half-maximal inhibitory concentration: 4630 nM
The estimate for compound 3 lay 4.3-fold (0.64 log units) above the measured number; the measured number falls inside the stated range.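

In this assay, for the compounds shown here, ethyl to isopropyl in the carbamoyl group is the first single change that can be read, and it gives an at least 27-fold lower number from compound 2 to compound 3 (1.44 log units; beyond the scatter). The value of compound 2 is a limit and not a number: the limit of > 128000 nM in this assay, at which 1 of the 3 values shown sits. With the isopropylcarbamoyl group held, 4-methylphenyl in place of 2-fluorophenyl gives a modest step, a 2.5-fold higher number from compound 1 to compound 3 (0.40 log units; beyond the scatter).

From the compounds shown here alone, how a tert-butyl or cyclopropyl group in place of isopropyl would read remains open. Also open, going by these compounds, is whether 2-fluorophenyl paired with the ethylcarbamoyl group would sit at a limit too.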